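The compounds below may be only part of what the source reports. "The series", "measured", "known", "first", "only" and "open" are said of these compounds alone.

Measured so far:
compound 1 `O=C(NCc1cn(Cc2ccc(C(F)(F)F)cc2)nn1)c1cn(-c2ccccc2)nc1-c1ccccc1` gives 840 nM
compound 2 `COc1cc(Cn2cc(CNC(=O)c3cn(-c4ccccc4)nc3-c3ccccc3)nn2)cc(OC)c1` gives 2400 nM

Within the data shown here, compound 1 holds the lower of the two numbers in a functional assay on MCF7 cells (Homo sapiens) for antiproliferative activity, read by sulforhodamine B assay, with a stated time of 48 h; a higher number here means a weaker inhibitor of growth, a lower number a stronger inhibitor of growth; the one recorded step, a 2.9-fold higher number from compound 1 to compound 2 (0.46 log units; beyond the scatter), separates it from compound 2. Compound 3 `O=C(NCc1cn(Cc2ccc(C(F)(F)F)cc2)nn1)c1cn(-c2ccccc2)nc1-c1ccc(F)cc1` differs from compound 1 in another part of the molecule: fluoro in place of hydrogen on an aromatic carbon, a change that reads, one bond further out, as phenyl to 4-fluorophenyl. Among the measured compounds shown here, the single measured step concerns the group on the saturated chain carbon bound to an aromatic nitrogen and leaves the ring altered here untouched, so no measured step bears on this change. With nothing pointing in either direction, the expected step of no change at the digits printed from compound 1 to compound 3 (within the scatter) is none beyond the scatter. Compound 3 is therefore estimated at 840 nM in this assay, within a range of 380 nM to 1900 nM.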

Compound 3, concentration for 50% growth inhibition: 810 nM
The estimate for compound 3 lay 1.0-fold (0.02 log units) above the measured number, within the range that was stated.
By their numbers in this assay, from the lowest: compounds 3 and 1 (each within the scatter of the next); then compound 2.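

Phenyl to 4-fluorophenyl moves the comparison away from the group on the saturated chain carbon, and in this assay it amounts to a 1.0-fold lower number from compound 1 to compound 3 (0.02 log units; within the scatter), so at this position, para to a large group, fluoro cannot be told from hydrogen. The step of a 2.9-fold higher number from compound 1 to compound 2 (0.46 log units; beyond the scatter) therefore remains the only one shown that lies beyond the scatter. No measurement at hand offers a reason for this result.

One fluoro leaves open whether other groups at this position, such as a methoxy, an amine or a carboxylic acid, would move the number. From the compounds shown here alone, it also remains open whether fluoro would read the same alongside the 3,5-dimethoxyphenyl of compound 2, and what a change on the other phenyl of the core would do.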